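Phenyl for pyridin-3-yl on the benzothiazole-bearing nitrile core

The source may report more compounds than this note shows. Statements on the series, on what has been measured and on what is new or still open speak of the compounds shown alone.

Measured so far:
compound 1 `N#Cc1cc(-c2ccc3scnc3c2)ccc1-c1cccnc1`, > 10000 nM
compound 2 `Cc1nc2cc(-c3cccc(C#N)c3)ccc2s1`, "not determined" (no result reported)
compound 3 `Cc1cccc(C#Cc2cncc(C#N)c2)n1`, 13 nM

In an in vitro functional assay on HEK293-A cells for antagonist activity at metabotropic glutamate receptor 5 (Rattus norvegicus), read by fluorescence and calcium flux, with a stated time of 140 s (on this read-out higher numbers stand for weaker inhibition and lower numbers for stronger inhibition), compound 1 gives only a limit, > 10000 nM, and not a number. For compound 2 this assay reports "not determined" (no result reported). Going by the values given here, compound 3, built on a different core, gives 13 nM in this assay; with no shared step to compound 1, the two values show only what each of them is, and nothing more is drawn from the pair. Compound 1 therefore stands at the weak end of what has been recorded, with one further entry that carries no number at all.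

Compound 4 `N#Cc1cc(-c2ccc3scnc3c2)ccc1-c1ccccc1` differs from compound 1 in one place: phenyl in place of pyridin-3-yl on an aromatic carbon, ortho to a cyano group and para to a group of 9 heavy atoms. Among the compounds with values here, no measured step of this kind exists in the set, so the expected size and direction rest on compound 1 alone. Because the limit of > 10000 nM in this assay, at which 1 of the 3 values shown sits, marks where compound 1 sits, compound 4 is expected to stay near that limit, with the step from compound 1 to compound 4 estimated as a step that the limit leaves unreadable from compound 1 to compound 4, not beyond the scatter. Compound 4 is thus estimated at 15000 nM, between 3000 nM and 60000 nM, most likely reported again only as a limit.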

Compound 4, half-maximal inhibitory concentration: 6890 nM
Estimate against measurement, compound 4: 2.2-fold (0.34 log units) above; the measured number falls inside the stated range.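

Going by these compounds alone, compound 4 gives 6890 nM in this assay and so provides the first single number on the core of compound 1, showing that this core can register in the assay once phenyl stands at this place. For compound 1 the entry > 10000 nM is a limit of the assay and not a number. Phenyl in place of pyridin-3-yl on an aromatic carbon, ortho to a cyano group and para to a group of 9 heavy atoms, reads only as an at least 1.4-fold lower number from compound 1 to compound 4 (0.16 log units; that floor lies within the scatter) and gives a floor on the step, not its size, so no gain from this change can be claimed: the limit of > 10000 nM in this assay, at which 1 of the 4 values shown sits.

Only phenyl and pyridin-3-yl are shown at this place, so it stays open how a carboxylic acid, a primary amine or a longer alkyl chain on the same carbon would read, and whether any of them would give a number closer to that of compound 4 or a limit like that of compound 1. Within the data shown here, no step links this core to compound 3 at 13 nM and compound 2 carries no number, so what separates these entries remains open.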